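The source may report more compounds than this note shows. Statements on the series, on what has been measured and on what is new or still open speak of the compounds shown alone.

Compound 1 `COc1cc2c(Oc3ccc(NC(=O)N/N=C/c4ccc(OC(F)(F)F)cc4)cc3F)ccnc2cc1OCCCN1CCCCC1` gives 630 nM in a functional assay on MKN-45 cells (Homo sapiens) for cytotoxicity, read by MTT assay, with a stated time of 72 h; a lower number here means a stronger inhibitor, a higher number a weaker inhibitor.
Compound 2 `COc1cc2c(Oc3ccc(NC(=O)N/N=C/c4ccc(O)cc4)cc3F)ccnc2cc1OCCCN1CCCCC1` gives 850 nM in this assay.

Among these two numbers, compound 2 holds the higher one, yet the step of a 1.3-fold higher number from compound 1 to compound 2 (0.13 log units; within the scatter) lies within the scatter, so the two compounds cannot be told apart on this evidence. Compound 3 `C=CCc1cccc(/C=N/NC(=O)Nc2ccc(Oc3ccnc4cc(OCCCN5CCCCC5)c(OC)cc34)c(F)c2)c1OC` has not yet been measured in this assay. It differs from compound 2 in 3-allyl-2-methoxyphenyl in place of 4-hydroxyphenyl on a carbon with a double bond to nitrogen. For the measured compounds named here, the single measured step, from compound 1 to compound 2, concerned only what sits on the oxygen of that same ring and changed nothing beyond the scatter; it bears only loosely on a change that exchanges the whole ring substituent pattern. Going by the values given here, with no measured step pointing in either direction, the expected step of a 1.1-fold lower number from compound 2 to compound 3 (0.05 log units; within the scatter) is none beyond the scatter. Compound 3 is therefore estimated at 750 nM, with a range from 250 nM to 2500 nM.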

Compound 3, half-maximal inhibitory concentration: 670 nM
Estimate against measurement, compound 3: 1.1-fold (0.05 log units) above, within the range that was stated.
By their numbers in this assay, from the lowest: compounds 1, 3 and 2 (each within the scatter of the next).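

Replacing the ring on the carbon with a double bond to nitrogen by 3-allyl-2-methoxyphenyl gives a 1.3-fold lower number from compound 2 to compound 3 (0.10 log units; within the scatter) and a 1.1-fold higher number from compound 1 to compound 3 (0.03 log units; within the scatter) in this assay. Where the earlier step altered only what sits on the ring's oxygen, this change replaces the whole substituted ring, going from 7 to 11 heavy atoms and, relative to compound 2, from 1 hydrogen-bond donor to 0, and the number still stays within the scatter. Nothing shown here gives a measured reason for this.

Still open, on these data alone, is whether any ring at this place would move the number beyond the scatter, for instance one carrying an amine or a carboxylic acid. As far as these compounds go, the allyl and methoxy groups also appear only together, so what each contributes alone remains unknown.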